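Changing the Sulfonyl Aryl Group of Compound 2

This account rests on a few compounds, and the source may have more. Where it says the series, first, only, none or still open, it means among the compounds named here.

In a functional assay on A2780 cells (Homo sapiens) for inhibition, read by sulforhodamine B assay, with a stated time of 72 h (a higher number here means a weaker inhibitor, a lower number a stronger inhibitor), compound 1 `O=C(NCc1ccc(S(=O)(=O)c2ccccc2)cc1)c1ccc2ncncc2c1` reads > 10000 nM, which is a limit and not a number. Compound 2 `O=C(NCc1ccc(S(=O)(=O)c2ccccc2C(F)(F)F)cc1)c1cc2cnccc2[nH]1` gives 25 nM, the higher of the two actual numbers, and compound 3 `O=C(NCc1ccc(S(=O)(=O)c2cc(F)cc(F)c2)cc1)c1cnc2nccn2c1` gives 3 nM. Compound 4 `O=C(NCc1ccc(S(=O)(=O)c2ccc(F)cc2)cc1)c1cc2cnccc2[nH]1` has 4-fluorophenyl in place of 2-(trifluoromethyl)phenyl on a sulfonyl sulfur. Going by the values given here, no measured pair isolates this change, so the guidance is thin. Compound 3, with a different core, also carries fluorine on the ring attached to its sulfonyl sulfur and reaches 3 nM. A modest move toward a lower number in this assay is therefore expected, slightly beyond the scatter. The expected change is a 2.5-fold lower number from compound 2 to compound 4 (0.40 log units; beyond the scatter). For compound 4 the estimated value is 10 nM, within an expected range of 2 nM to 50 nM.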

Compound 4, half-maximal inhibitory concentration: 16 nM
Compound 4: middle estimate off by 1.6-fold (0.20 log units), on the low side, and the stated range covers the measured number.
By their numbers in this assay, from the lowest: compound 3; then compounds 4 and 2 (each within the scatter of the next). At a limit, above all of these: compound 1.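

In this assay, the first pair differing in one place shows a 1.6-fold lower number from compound 2 to compound 4 (0.19 log units; within the scatter), so 4-fluorophenyl and 2-(trifluoromethyl)phenyl on a sulfonyl sulfur cannot be told apart here with the shared core of compound 2 and compound 4. This single step replaces one substituted ring with another, so it cannot separate the loss of trifluoromethyl from the gain of fluorine. Nothing shown offers a measured explanation for this result. Still open, as far as these compounds go, is how this position would respond to a ring carrying an amine or a carboxylic acid.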